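Changing the Pyridine Group on a Shared Sulfonamide Core

A few compounds are considered here, and "the series" means these few. Any claim that something is new, unique, unknown or untested is made for them only; others in the source may bear on it.

Compound 1 `CC1(C)[C@@H]2CC[C@@]1(CS(=O)(=O)N1CCN(c3ncccc3C(F)(F)F)CC1)C(=O)C2` was tested in a functional assay on CHO-K1 cells for antagonist activity at C-X-C chemokine receptor type 3 (Homo sapiens), read by FLIPR and calcium flux (on this read-out lower numbers stand for stronger inhibition and higher numbers for weaker inhibition), and compound 1 gives > 31600 nM there, which is a limit of the assay and not a number. Two relatives were measured with numbers: compound 2 `CC1CN(S(=O)(=O)C[C@]23CC[C@H](CC2=O)C3(C)C)CCN1c1ccc(C(F)(F)F)cn1` gives 316 nM in this assay, and compound 3 `C[C@H]1CN(S(=O)(=O)C[C@]23CC[C@H](CC2=O)C3(C)C)CCN1c1ccc(C(F)(F)F)cn1` gives 158 nM. The only single-place step among the measured compounds is a 2.0-fold lower number from compound 2 to compound 3 (0.30 log units; within the scatter), and it concerns just how a ring stereocentre is drawn, as shown by the fact that one of compounds 2 and 3 is drawn with a defined configuration and the other without, at the place where they differ, not which groups hang on the core. Compound 4 `Cc1ccc(N2CCN(S(=O)(=O)C[C@]34CC[C@H](CC3=O)C4(C)C)CC2)nc1` differs from compound 1 by 5-methylpyridin-2-yl in place of 3-(trifluoromethyl)pyridin-2-yl on an amine nitrogen in a ring. For the measured compounds named here, compounds 2 and 3 differ from compound 1 in more than one place, so no measured step bears directly on this change; the evidence is confined to the limit of > 31600 nM in this assay, at which 1 of the 3 values shown sits, for compound 1. The direction of the change is therefore uncertain, but compound 4 is estimated at 3000 nM, with a range from 300 nM to 30000 nM. This estimate means an expected step of an at least 10-fold lower number from compound 1 to compound 4 (1.02 log units; beyond the scatter), with a real chance that only a limit is reported again.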

Compound 4, half-maximal inhibitory concentration: > 31600 nM
Compound 4 gave a limit, no number; the forecaster's own chance of this, stated with the estimate: 30%; middle value at least 10-fold (1.02 log units) from the limit.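

Compound 1 and compound 4 each give only a limit of the assay and not a number, so the step between them cannot be read. The compounds shown leave open whether 5-methylpyridin-2-yl in place of 3-(trifluoromethyl)pyridin-2-yl changes inhibition in this assay at all.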